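The compounds below may be only part of what the source reports. "The series", "measured", "known", "first", "only" and "open" are said of these compounds alone.

Compound 1 `Cc1cc(O)c(C2=NN(c3ccc(S(N)(=O)=O)cc3)C(c3ccccc3O)C2)cc1Cl` and compound 2 `COc1ccc(C2CC(c3cc(Cl)c(C)cc3O)=NN2c2ccc(S(N)(=O)=O)cc2)cc1OC` share one core and differ only in the group carried on a saturated ring carbon. In a functional assay on SK-MEL-2 cells (Homo sapiens) for antiproliferative activity, with a stated time of 48 h (on this read-out higher numbers stand for lower toxicity in this test and lower numbers for higher toxicity in this test), compound 1 gives 67000 nM. For compound 2 the assay reports only a limit, > 100000 nM, and no number. As far as these compounds go, the step of an at least 1.4-fold higher number from compound 1 to compound 2 (0.17 log units; that floor lies within the scatter) is therefore itself only a floor, and compound 2 stands at the limit of > 100000 nM in this assay, at which 1 of the 2 values shown sits, so its true position is unknown beyond that.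

Compound 3 `COc1ccc(C2CC(c3cc(Cl)c(C)cc3O)=NN2c2ccc(S(N)(=O)=O)cc2)c(OC)c1OC` differs from compound 2 in one place: methoxy in place of hydrogen on an aromatic carbon. Within the data shown here, no measured step tests this kind of change. Among the measured compounds shown here, the only measured step, an at least 1.4-fold higher number from compound 1 to compound 2 (0.17 log units; that floor lies within the scatter), concerns a different group at a different position and ends at the limit, so it offers no size for adding a methoxy group. The expected step of a number no higher from compound 2 to compound 3 (the limit leaves the size open) is small, because compound 2 already sits at the limit of > 100000 nM in this assay, at which 1 of the 2 values shown sits, and the read-out can hardly move further in that direction. Compound 3 is therefore expected to give 100000 nM, within a range from 50000 nM to 200000 nM, most likely again reported only as a limit.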

Compound 3, concentration lethal to 50% of the cells: 71300 nM
Compound 3: the middle estimate sits 1.4-fold (0.15 log units) above what was measured, within the range that was stated.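

In this assay, placing a methoxy group on this aromatic carbon gives an at least 1.4-fold lower number from compound 2 to compound 3 (0.14 log units; that floor lies within the scatter), so the added group yields a measured number where the 3,4-dimethoxyphenyl compound gave none, although this floor alone shows no change beyond the scatter. Compound 2 remains a limit and not a number, so the true size of this step cannot be read: the limit of > 100000 nM in this assay, at which 1 of the 3 values shown sits. The 2,3,4-trimethoxyphenyl group can also be set against the 2-hydroxyphenyl group on the saturated ring carbon, with a 1.1-fold higher number from compound 1 to compound 3 (0.03 log units; within the scatter), so these two groups cannot be told apart on this read-out.

The compounds shown leave open where the true value of compound 2 lies, and so whether the methoxy group on this carbon matters at all beyond the scatter. They also leave open whether a different group on the same aromatic carbon, such as an amine, a carboxylic acid or a longer ether chain, would move the number clearly away from that of compound 3.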